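Series notes: chain length and aryl amide swap

This account rests on a few compounds, and the source may have more. Where it says the series, first, only, none or still open, it means among the compounds named here.

Three compounds of this series have structures recorded: compound 1 `CC(C)COc1ccc(NC(=O)CCCCCCCSc2nnc(Cc3nn(C)c(=O)c4ccccc34)n2C)cc1`, compound 2 `CCCOc1ccc(NC(=O)CCCCCCCSc2nnc(Cc3nn(C)c(=O)c4ccccc34)n2C)cc1` and compound 3 `Cn1c(Cc2nn(C)c(=O)c3ccccc23)nnc1SCC(=O)Nc1ccc(Cl)cc1Cl`. Among the measured compounds shown here, in an assay on isolated protein for binding affinity to interleukin-2 (Homo sapiens), read by surface plasmon resonance (on this read-out higher numbers stand for weaker binding and lower numbers for tighter binding), compound 3 gives 10500 nM, and this is the only number the series holds. In this assay compound 2 gives "not determined" (no result reported). In this assay compound 1 gives "not determined" (no result reported). Compound 2 therefore has no value to stand on. Compound 4 `Cn1c(Cc2nn(C)c(=O)c3ccccc23)nnc1SCCCCCCCC(=O)Nc1ccc(Br)cc1Br` is to be measured next. Compound 4 differs from compound 2 in one place: 2,4-dibromophenyl in place of 4-propoxyphenyl on an amide-type nitrogen. For the measured compounds named here, with no measured step of any kind, the direction and size of this change cannot be read from the data. Going by the values given here, on the single number of compound 3 in this assay, 10500 nM, compound 4 is expected near 10000 nM, in a wide range from 2000 nM to 50000 nM.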

Compound 4, dissociation constant: 10000 nM
Beside the measured number, compound 4's estimate shows no gap at the digits printed; measured number inside the range.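

No new step can be read: compound 2 has no value to set against compound 4 at 10000 nM. As far as these compounds go, what swapping 4-propoxyphenyl for 2,4-dibromophenyl does to binding stays open. No supporting evidence bears on this result.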